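Furan-3-ylmethylamine replaces the sulfonamide on the piperidine ring

This account rests on a few compounds, and the source may have more. Where it says the series, first, only, none or still open, it means among the compounds named here.

Compound 1 `c1ccc(CNCC2CCN(CCCc3c[nH]c4ccc(-n5cnnc5)cc34)CC2)cc1`: 1.6 nM
Compound 2 `CN(Cc1cccs1)C1CCN(CCCc2c[nH]c3ccc(-n4cnnc4)cc23)CC1`: 4.3 nM
Compound 3 `CN(C1CCN(CCCc2c[nH]c3ccc(-n4cnnc4)cc23)CC1)S(=O)(=O)c1ccccc1`: 1.5 nM

Of the compounds shown here, three sharing one core have been measured in an assay on CHO cells for displacement of a labelled ligand from 5-hydroxytryptamine receptor 1D (Homo sapiens); on this read-out higher numbers stand for weaker inhibition and lower numbers for stronger inhibition. Compound 3 gives the lowest number of the three, although one of its gaps is only a 1.1-fold lower number from compound 1 to compound 3 (0.03 log units; within the scatter) and lies within the scatter, while the other, a 2.9-fold lower number from compound 2 to compound 3 (0.46 log units; beyond the scatter), lies beyond it. Compound 4 `c1cc(CNC2CCN(CCCc3c[nH]c4ccc(-n5cnnc5)cc34)CC2)co1` has not yet been measured. Its change from compound 3 is ((furan-3-yl)methyl)amino in place of methyl(phenylsulfonyl)amino on a saturated ring carbon. The step that bears most on it is a 2.9-fold lower number from compound 2 to compound 3 (0.46 log units; beyond the scatter), where exchanging a heteroarylmethyl group for the phenylsulfonyl group lowered the number modestly; going back from the sulfonamide to a heteroarylmethyl amine in compound 4 is expected to reverse that, so a modest rise is expected. The secondary amine of compound 1 with its 1.6 nM shows that a free amine hydrogen need not raise the number. Compound 4 is therefore expected at 3.5 nM, within 1.2 nM to 10 nM, an expected step of a 2.3-fold higher number from compound 3 to compound 4 (0.37 log units; beyond the scatter).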

Compound 4, half-maximal inhibitory concentration: 4.5 nM
Beside the measured number, compound 4's estimate is 1.3-fold (0.11 log units) below it; low and high end bracket the measured number.
By their numbers in this assay, from the lowest: compounds 3 and 1 (each within the scatter of the next); then compounds 2 and 4 (each within the scatter of the next).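

In this assay, the ((furan-3-yl)methyl)amino group on the saturated ring carbon does not hold the level of the methyl(phenylsulfonyl)amino group, with a 3.0-fold higher number from compound 3 to compound 4 (0.48 log units; beyond the scatter), and it also stands apart from the (benzylamino)methyl group, with a 2.8-fold higher number from compound 1 to compound 4 (0.45 log units; beyond the scatter). Against the methyl((thiophen-2-yl)methyl)amino group there is no real difference, with a 1.0-fold higher number from compound 2 to compound 4 (0.02 log units; within the scatter), so at this position the furan and thiophene amines read alike, even though they differ in ring and in the methyl on the nitrogen. No measurement shown accounts for these steps.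

The compounds shown leave open whether a methyl group on the amine nitrogen of compound 4 would shift the number. They also leave open whether a benzoyl amide in place of the phenylsulfonyl group would stay level with compound 3.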